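The compounds below may be only part of what the source reports. "The series", "measured", "known", "first", "only" and "open" are said of these compounds alone.

Within the data shown here, in an ADME assay on HepG2 cells (Homo sapiens) for cytotoxicity, with a stated time of 72 h (a lower number here means that less compound is needed, a higher number that more compound is needed for the effect), compound 1 `Cc1cc(NC(=O)Nc2cccc(Cl)c2)c2ccccc2n1` gives 19000 nM, the only numerical value in the set. For compound 2 `Cc1cc(NC(=O)Nc2ccc(F)cc2)c2ccccc2n1` the readout is a limit of the assay, > 25000 nM; this is the limit of > 25000 nM in this assay, at which 1 of the 2 values shown sits. Among the measured compounds shown here, the one measured step, an at least 1.3-fold higher number from compound 1 to compound 2 (0.11 log units; that floor lies within the scatter), lies within the scatter. Compound 3 `Cc1cc(NC(=O)Nc2cccc(C(C)(C)C)c2)c2ccccc2n1` differs from compound 1 by tert-butyl in place of chloro on an aromatic carbon. For the measured compounds named here, no measured step covers a tert-butyl group, and the single step available is small, so no shift beyond the scatter is expected. Compound 3 is estimated at 20000 nM, between 9000 nM and 45000 nM. The expected step of a 1.1-fold higher number from compound 1 to compound 3 (0.02 log units; within the scatter) stays within the scatter, with a fair chance that only a limit is reported.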

Compound 3, half-maximal effective concentration: > 25000 nM
Compound 3: no number, only a limit (the forecaster's own chance of this, stated with the estimate: 40%); middle value at least 1.2-fold (0.09 log units) from the limit.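

In this assay compound 3 gives only a limit, > 25000 nM. Tert-butyl in place of chloro on this aromatic carbon gives an at least 1.3-fold higher number from compound 1 to compound 3 (0.11 log units; that floor lies within the scatter), so no shift beyond the scatter can be claimed for this change. With compound 3, a change on the aryl ring again ends at a limit rather than at a number: the limit of > 25000 nM in this assay, at which 2 of the 3 values shown sit.

Among these compounds, the true size of this step stays open, with compound 1 still the only numerical value. Also open, from the compounds shown here alone, is whether an amine or a carboxylic acid on this carbon would give a lower number.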